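Swapping the nitro for isopropoxy on the phenyl ring

The source may hold more compounds than are shown below. What is called first, only, known or untested is meant among the compounds shown, and "the series" means these compounds.

Measured so far:
compound 1 `O=C(O)c1cnc(-c2ccccc2)[nH]c1=O` gives 50 mg/kg
compound 2 `O=C(O)c1cnc(-c2ccccc2[N+](=O)[O-])[nH]c1=O` gives > 50 mg/kg
compound 3 `CCCOc1ccccc1-c1ncc(C(=O)O)c(=O)[nH]1` gives 0.9 mg/kg

All three compounds share one core and differ only in the group on the phenyl ring. In a functional assay on the whole organism (strain Sprague-Dawley) for inhibition, with Rattus norvegicus as the target, with a stated time of 10 min (a lower number here means that less compound is needed, a higher number that more compound is needed for the effect), compound 1 gives 50 mg/kg. Compound 2 carries a nitro group and gives only a limit of the assay, > 50 mg/kg, so its true value is not known (the limit of > 50 mg/kg in this assay, at which 1 of the 3 values shown sits). Compound 3 carries a propoxy group and gives 0.9 mg/kg; the steps of a 56-fold lower number from compound 1 to compound 3 (1.74 log units; beyond the scatter) and an at least 55-fold lower number from compound 2 to compound 3 (1.74 log units; beyond the scatter) are both large, while a number no lower from compound 1 to compound 2 (the limit leaves the size open) cannot be sized.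

The unmeasured compound 4 `CC(C)Oc1ccccc1-c1ncc(C(=O)O)c(=O)[nH]1` takes the same path as compound 3 from compound 2: isopropoxy in place of nitro on an aromatic carbon. Propoxy and isopropoxy are both alkoxy groups of similar size, so the step from compound 2 to compound 4 is expected to resemble the large step from compound 2 to compound 3. The estimated step is an at least 33-fold lower number from compound 2 to compound 4 (1.52 log units; beyond the scatter). Compound 4 is thus expected to give about 1.5 mg/kg, with a likely range of 0.5 mg/kg to 6 mg/kg.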

Compound 4, dose for 50% inhibition: 0.8 mg/kg
Compound 4: the middle estimate sits 1.9-fold (0.27 log units) above what was measured; low and high end bracket the measured number.
By their numbers in this assay, from the lowest: compounds 4 and 3 (each within the scatter of the next); then compound 1.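

In this assay, the branched isopropoxy and the straight propoxy cannot be told apart on this aromatic carbon, ortho to a large group: a 1.1-fold lower number from compound 3 to compound 4 (0.05 log units; within the scatter). A second alkoxy group now shows the same large change, so the effect does not depend on one chain shape, with a 63-fold lower number from compound 1 to compound 4 (1.80 log units; beyond the scatter) and an at least 62-fold lower number from compound 2 to compound 4 (1.79 log units; beyond the scatter). Compound 2 stands only at a limit, so the last of these steps has no fixed size: the limit of > 50 mg/kg in this assay, at which 1 of the 4 values shown sits.

From the compounds shown here alone, how a shorter methoxy group, a longer butoxy chain or an amine would read at this place stays open. Also open, going by these compounds, is whether the oxygen itself matters, a question that a butyl group bonded directly to the aromatic carbon could help to answer.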